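Swapping the Hydroxyphenyl for a Pyridinyl Ring

A few compounds are considered here, and "the series" means these few. Any claim that something is new, unique, unknown or untested is made for them only; others in the source may bear on it.

Of the compounds shown here, three built on one shared core have been measured in an assay on CHO cells for displacement of a labelled ligand from Alpha-2B adrenergic receptor (Homo sapiens); on this read-out higher numbers stand for weaker inhibition and lower numbers for stronger inhibition. Compound 1 `CC(Oc1ccccc1-c1ccccc1)C1=NCCO1` gives 10000 nM. Compound 2 `CC(Oc1ccccc1-c1ccc(O)cc1)C1=NCCN1` gives 813 nM, and compound 3 `CC(Oc1ccccc1-c1ccc([N+](=O)[O-])cc1)C1=NCCN1` gives 501 nM. Compound 2 thus holds the second highest of the three numbers: its nearest neighbour is compound 3, while compound 1 sits furthest away with a much higher number, which points to weaker binding. Compound 4 `CC(Oc1ccccc1-c1ccccn1)C1=NCCN1` differs from compound 2 in a single place: pyridin-2-yl in place of 4-hydroxyphenyl on an aromatic carbon. Among the compounds with values here, only one measured step bears on this change, the one in which the group on that same aromatic carbon was altered, giving a 1.6-fold lower number from compound 2 to compound 3 (0.21 log units; within the scatter). Within the data shown here, no measured step replaces the whole ring, and the group that enters brings no hydrogen-bond donor, so the expectation rests on thin ground. Compound 4 is expected to show a 1.1-fold higher number from compound 2 to compound 4 (0.04 log units; within the scatter) in this assay. The estimate for compound 4 is 900 nM, within 300 nM to 2700 nM.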

Compound 4, inhibition constant: 3310 nM
The estimate for compound 4 lay 3.7-fold (0.57 log units) below the measured number, and the stated range ends below it.
By their numbers in this assay, from the lowest: compounds 3 and 2 (each within the scatter of the next); then compound 4; then compound 1.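

Within the data shown here, until now, the only measured change on this aromatic carbon was a swap of one group on the outer ring, and that step stayed within the scatter. Replacing the whole ring has a clearer effect in this assay: pyridin-2-yl in place of 4-hydroxyphenyl gives a 4.1-fold higher number from compound 2 to compound 4 (0.61 log units; beyond the scatter), so this position does respond to what it carries, if only modestly. No measurement available here explains this rise, and the change alters the ring and removes the hydroxy group's hydrogen-bond donor at once.

The compounds shown cannot separate the effect of the ring nitrogen from that of the missing hydroxy group, which a plain phenyl ring on the core of compound 2 could help to do. Going by these compounds, whether an amine in place of the hydroxy group would keep the number near that of compound 2 also remains open.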